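The source may report more compounds than this note shows. Statements on the series, on what has been measured and on what is new or still open speak of the compounds shown alone.

In an ADME assay on MRC5 cells (Homo sapiens) for cytotoxicity, read by fluorescence and resazurin assay, with a stated time of 3 days (on this read-out higher numbers stand for weaker inhibition and lower numbers for stronger inhibition), compound 1 `Cc1cn(C2CCN(Cc3cccc(Oc4ccccn4)c3)CC2)c(=O)[nH]c1=O` gives > 64000 nM as a limit of the assay and not a number. Compound 2 `Cc1cn(C2CCN(Cc3cccc(Oc4ccccc4)c3)CC2)c(=O)[nH]c1=O` stands at "not determined" (no result reported) and so has no single number of its own. Compound 3 `Cc1cn(C2CCN(Cc3cccc(Oc4ccc(Cl)c(Cl)c4)c3)CC2)c(=O)[nH]c1=O` is not yet measured. The structural change is 3,4-dichlorophenyl in place of phenyl on an oxygen on an aromatic ring with 3,4-dichlorophenyl in place of phenyl on an oxygen on an aromatic ring. Among the compounds with values here, no measured step sets the size, so only a modest move towards stronger inhibition in this assay is expected, probably beyond the scatter. For compound 3 the estimated value is 20000 nM with an expected range of 6000 nM to 64000 nM on the same read-out.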

Compound 3, half-maximal inhibitory concentration: 6100 nM
Compound 3: the middle estimate sits 3.3-fold (0.52 log units) above what was measured, and the stated range covers the measured number.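

In this assay, 3,4-dichlorophenyl on the oxygen brings a measurable cytotoxicity into the series, with an at least 10-fold lower number from compound 1 to compound 3 (1.02 log units; beyond the scatter) in place of pyridin-2-yl. This position is therefore not silent in this assay. The value of compound 1 is a limit of the assay and not a number, and the true size of the step stays unfixed: the limit of > 64000 nM in this assay, at which 1 of the 3 values shown sits.

Going by these compounds, compound 2 has no result, so the step from phenyl to 3,4-dichlorophenyl cannot be read, and the share of the two chlorines stays open. Also open, on these data alone, is how a carboxylic acid or an amine on this aromatic ring would read in this assay.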